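Trimming one methoxy from a trimethoxyphenyl pyrazole chalcone

This account rests on a few compounds, and the source may have more. Where it says the series, first, only, none or still open, it means among the compounds named here.

Three compounds share a core in which a pyrazole carries an aryl ring on one side and an enone on the other. In a functional assay on Hs-578T cells (Homo sapiens) for cytotoxicity, read by sulforhodamine B assay, with a stated time of 48 h, tested at 10 uM (a higher number here means a weaker effect of the compound at the concentration tested, a lower number a stronger effect), compound 2 `COc1cc(-c2cc(/C=C/C(=O)c3ccc(N)cc3)[nH]n2)cc(OC)c1OC` gives 29%, the highest of the three numbers, while compound 1 `COc1ccc(-c2cc(/C=C/C(=O)c3ccc(N)cc3)[nH]n2)cc1` gives 22% and compound 3 `COc1cc(-c2cc(/C=C/C(=O)c3ccc(F)c(F)c3)[nH]n2)cc(OC)c1OC` gives 21%; both gaps to compound 2 fall within the scatter. Among the measured compounds shown here, the one measured step, a number 8 percentage points lower from compound 2 to compound 3 (within the scatter), alters the other end of the molecule and therefore says little about the change at hand. Compound 4 `COc1ccc(-c2cc(/C=C/C(=O)c3ccc(N)cc3)[nH]n2)cc1OC` differs from compound 2 by hydrogen in place of methoxy on an aromatic carbon. Compound 1, with a single methoxy, and compound 2, with three, sit within the scatter of each other, so for compound 4 no step beyond the scatter is expected, a number 4 percentage points lower from compound 2 to compound 4 (within the scatter), and a value of 25% within 12% to 40% is estimated.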

Compound 4, a percentage reported as activity, at one concentration (the size of the read-out at that concentration, not a potency): 40%
For compound 4 the middle estimate is 15 percentage points below the measured one, and the stated range covers the measured number.
By their numbers in this assay, from the lowest: compounds 3, 1 and 2 (each within the scatter of the next); then compound 4.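

Hydrogen in place of methoxy weakens the effect in this assay, as a number 11 percentage points higher from compound 2 to compound 4 (beyond the scatter) shows, and methoxy in place of hydrogen also weakens it, as a number 18 percentage points higher from compound 1 to compound 4 (beyond the scatter) shows. Both changes on this ring thus move the number the same way, so across compounds 1, 4 and 2 the effect does not simply follow how many methoxy groups the ring carries. No measurement at hand explains this. As far as these compounds go, whether the same holds with the 3,4-difluorophenyl end of compound 3 remains open. So does how a hydroxyl or an ethoxy group would behave at this place.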